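The source may hold more compounds than are shown below. What is called first, only, known or untested is meant among the compounds shown, and "the series" means these compounds.

Working notes on the series. Three compounds are measured in a functional assay on K562 cells (Homo sapiens) for cytotoxicity, read by MTT assay, with a stated time of 72 h (a higher number here means a weaker inhibitor, a lower number a stronger inhibitor), and one is not. Compound 1 `CCCCOCNc1n[n+]([O-])c2ccccc2[n+]1[O-]` gives 17600 nM. Compound 2 `CCOCNc1n[n+]([O-])c2ccccc2[n+]1[O-]` gives 15400 nM. Compound 3 `CCCCCCCOCNc1n[n+]([O-])c2ccccc2[n+]1[O-]` gives 2970 nM, the lowest number of the three, beyond the scatter from both others. Compound 4 `CCCCCOCNc1n[n+]([O-])c2ccccc2[n+]1[O-]` awaits measurement in this assay.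

Compound 2 differs from compound 1 by hydrogen in place of ethyl on a saturated chain carbon, two bonds along the chain from an oxygen on a saturated carbon; the step is a 1.1-fold lower number from compound 1 to compound 2 (0.06 log units; within the scatter). Compound 3 differs from compound 1 by propyl in place of hydrogen on a saturated chain carbon, four bonds along the chain from an oxygen on a saturated carbon, and the step is a 5.9-fold lower number from compound 1 to compound 3 (0.77 log units; beyond the scatter); against compound 2 the step is a 5.2-fold lower number from compound 2 to compound 3 (0.71 log units; beyond the scatter).

Compound 4 differs from compound 3 by hydrogen in place of ethyl on a saturated chain carbon, five bonds along the chain from an oxygen on a saturated carbon. This is the same kind of change as that from compound 1 to compound 2, not the same: there it sits two bonds along the chain from an oxygen on a saturated carbon, here five bonds along the chain from an oxygen on a saturated carbon. The earlier step was within the scatter, yet compound 3 stands apart from both others, and compound 4 lies between them in chain.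

Compound 4 is expected to give 8000 nM, a step of a 2.7-fold higher number from compound 3 to compound 4 (0.43 log units; beyond the scatter) beside a 1.1-fold lower number from compound 1 to compound 2 (0.06 log units; within the scatter), resting on compound 3 at 2970 nM and compound 1 at 17600 nM. For compound 4 the expected range runs from 3500 nM to 18000 nM.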

Compound 4, half-maximal inhibitory concentration: 14500 nM
Compound 4: the middle estimate sits 1.8-fold (0.26 log units) below what was measured, and the stated range covers the measured number.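

In this assay, the step of a 4.9-fold higher number from compound 3 to compound 4 (0.69 log units; beyond the scatter) finds no match in the same exchange of ethyl for hydrogen on the shorter chain, so this change does not carry from one core to another in this series: the same change on two cores in this assay, a 1.1-fold lower number (0.06 log units; within the scatter) from compound 1 to compound 2 and a 4.9-fold higher number (0.69 log units; beyond the scatter) from compound 3 to compound 4, 5.6-fold (0.75 log units) apart, beyond the scatter of two such steps

Read as chain lengthening, the pairs disagree in the same way, with a 1.1-fold lower number from compound 2 to compound 4 (0.03 log units; within the scatter) and a 1.2-fold lower number from compound 1 to compound 4 (0.08 log units; within the scatter) both within the scatter, unlike the step to compound 3: the same change on two cores in this assay, a 5.9-fold lower number (0.77 log units; beyond the scatter) from compound 1 to compound 3 and a 1.1-fold lower number (0.03 log units; within the scatter) from compound 2 to compound 4, 5.6-fold (0.75 log units) apart, beyond the scatter of two such steps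

This shows that compound 3 stands apart from the other three compounds, but it does not show why, and two pairs of steps cannot separate a trend with chain length from a result confined to compound 3.

The compounds shown leave open whether a longer chain than that of compound 3 keeps the lower number. They also leave open how a chain ending in an amine or a carboxylic acid would read in this assay.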